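Nitro in place of butoxy in a weak inhibitor series

A few compounds are considered here, and "the series" means these few. Any claim that something is new, unique, unknown or untested is made for them only; others in the source may bear on it.

Three related compounds have been measured so far in a functional assay (Homo sapiens) for inhibition (on this read-out lower numbers stand for stronger inhibition and higher numbers for weaker inhibition), and all show high numbers. Compound 1 (`CCCc1cc(/C=C/C(=O)c2ccc(O)cc2)c(OC)cc1O`) gives 41000 nM there and compound 2 (`CCCCOc1ccccc1C(=O)/C=C/c1cc(OC)cc(OC)c1`) gives 13000 nM there, while compound 3 (`CCCCOc1ccccc1/C=C/C(=O)c1ccc(OC)c(OC)c1OC`) gives 52000 nM there. Compound 3 lies within the scatter of compound 1 and has a clearly higher number than compound 2, which means weaker inhibition than compound 2.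

Compound 4 (`COc1ccc(C(=O)/C=C/c2ccccc2[N+](=O)[O-])c(OC)c1OC`) has not been measured yet. It carries nitro in place of butoxy on an aromatic carbon, ortho to a large group (nitro in place of butoxy on an aromatic carbon). Among the measured compounds shown here, no measured pair shows this exchange, so any expectation here is loose. The values span a modest range, with compound 2 at 13000 nM and compound 3 at 52000 nM as its ends, so no step beyond the scatter is expected in this assay for this change. The expected result is a slightly lower number, an estimated step of a 1.5-fold lower number from compound 3 to compound 4 (0.17 log units; within the scatter) that stays within the scatter. Compound 4 is estimated at 35000 nM with 10000 nM to 110000 nM as the likely range.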

Compound 4, half-maximal inhibitory concentration: 7000 nM
Beside the measured number, compound 4's estimate is 5.0-fold (0.70 log units) above it; the measured number lies below the stated range.
By their numbers in this assay, from the lowest: compounds 4 and 2 (each within the scatter of the next); then compounds 1 and 3 (each within the scatter of the next).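

In this assay, putting nitro in place of butoxy on this aromatic carbon, ortho to a large group, gives a 7.4-fold lower number from compound 3 to compound 4 (0.87 log units; beyond the scatter) and so moves the number beyond the usual scatter. Among the compounds shown here, this is the first exchange that can be read at a single place, and it shows that the group held here matters for inhibition. The entering nitro has 3 heavy atoms against the 5 of butoxy, but no measurement at hand explains the change.

As far as these compounds go, whether an amine, a carboxylic acid or a shorter ether chain such as ethoxy at this place would match nitro remains open. Also open, from the compounds shown here alone, is whether the same exchange would lower the number on the core of compound 2, which carries its butoxy on a differently built framework.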